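The source may hold more compounds than are shown below. What is called first, only, known or untested is meant among the compounds shown, and "the series" means these compounds.

Working notes on the series, an ADME assay on cells (Hepatocyte, Homo sapiens) for metabolic stability, with a stated time of 30 min; a lower number here means that less of the compound is left, a higher number that more of the compound is left.

Measured so far:
- compound 1 `Nc1cc(C(F)(F)F)cc2c(=O)cc(N3CCN(CC4CCCCC4)CC3)sc12`: compound 1 gives 0.9%
- compound 2 `O=C(OC1CCC(CN2CCN(c3cc(=O)c4cc(C(F)(F)F)cc([N+](=O)[O-])c4s3)CC2)CC1)c1ccco1`: compound 2 gives 1%
- compound 3 `O=c1cc(N2CCN(CC3CCCCC3)CC2)sc2c(NO)cc(C(F)(F)F)cc12`: compound 3 gives 19.1%

Where compound 2 stands: its number and that of compound 1 lie within the scatter of each other, so no order can be read between the two. For the measured compounds named here, compound 3 sits beyond the scatter above compound 2, as the only value in the set that clears the scatter.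

Going by the values given here, the one step available, a number 18.2 percentage points higher from compound 1 to compound 3 (beyond the scatter), concerns a change on a nitrogen on the shared core. Among the compounds with values here, it is the sole measured step and it does not touch the ester end of the molecule, which is where compound 4 `O=C(OC1CCC(CN2CCN(c3cc(=O)c4cc(C(F)(F)F)cc([N+](=O)[O-])c4s3)CC2)CC1)c1ccc(C(F)(F)F)cc1` differs from compound 2: 4-(trifluoromethyl)phenyl in place of furan-2-yl on a carbonyl carbon. Within the data shown here, no measured pair shows what an exchange at the ester aryl does in this assay, so there is nothing to read across from; the step to compound 3 was modest and rested on a different change.

Among the measured compounds shown here, with no step bearing on the ester aryl, the working expectation is a number close to that of compound 2, a step not beyond the scatter. The estimated step from compound 2 to compound 4 is a number 2 percentage points higher from compound 2 to compound 4 (within the scatter). For compound 4 the expected value is 3%, with a range from 0.5% to 12%.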

Compound 4, percent of the compound remaining: 5.2%
Compound 4: the middle estimate sits 2.2 percentage points below what was measured, and the stated range covers the measured number.
By their numbers in this assay, from the lowest: compounds 1, 2 and 4 (each within the scatter of the next); then compound 3.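

In this assay, for the compounds shown here, the exchange of furan-2-yl for 4-(trifluoromethyl)phenyl on a carbonyl carbon gives a number 4.2 percentage points higher from compound 2 to compound 4 (within the scatter) and is the first measured step at the ester end of the molecule. This position therefore accepts a six-membered aromatic ring of carbon only, with 10 heavy atoms entering for 5 and the hetero atom of the furan gone, without a step that clears the scatter, so this read-out does not separate the two aryl groups. No measurement on hand offers an explanation for how closely compound 2 and compound 4 read, and none links this result to any property of the two groups.

Open, on these data alone, is whether any group on this carbonyl carbon can give a step beyond the scatter, for instance a saturated cyclohexyl ring, a longer alkyl chain, or an aryl ring bearing a carboxylic acid or an amine. Also open, as far as these compounds go, is whether an amide in place of the ester oxygen would read differently, and whether the ester aryl exchange gives a similar step on a core carrying the hydroxyamino group of compound 3.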